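The compounds below may be only part of what the source reports. "The series", "measured", "known", "first", "only" and "open" are said of these compounds alone.

Of the compounds shown here, three sharing one core have been tested in an assay on 1321N1 cells for antagonist activity at P2Y purinoceptor 6 (Homo sapiens), read by FLIPR and calcium flux; on this read-out lower numbers stand for stronger inhibition and higher numbers for weaker inhibition. Compound 1 `O=[N+]([O-])C1=Cc2cccc(I)c2OC1C(F)(F)F` gives 4090 nM. Compound 3 `O=[N+]([O-])C1=Cc2cc(Cl)ccc2OC1C(F)(F)F` gives 1790 nM. Compound 2 `O=[N+]([O-])C1=Cc2cc(C#Cc3ccc(F)cc3)ccc2OC1C(F)(F)F` gives 8860 nM, the highest of the three numbers: its gap to compound 1 and its larger gap to compound 3 both lie beyond the usual scatter, so compound 2 is the weakest inhibitor among the measured compounds.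

Compound 4 `COC(=O)c1ccc(C#Cc2ccc3c(c2)C=C([N+](=O)[O-])C(C(F)(F)F)O3)cc1` has not yet been measured. It differs from compound 2 in one place: methoxycarbonyl in place of fluoro on an aromatic carbon. Among the compounds with values here, no pair of measured compounds shows this particular swap, so nothing here tells how it will act on the read-out. Without such a guide, the change is expected to leave the number about where it stands, with a step no larger than the usual scatter. The expected step from compound 2 to compound 4 in this assay is a 1.3-fold lower number from compound 2 to compound 4 (0.10 log units; within the scatter). Compound 4 is therefore estimated at 7000 nM in this assay, with a range from 2500 nM to 20000 nM.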

Compound 4, half-maximal inhibitory concentration: 3970 nM
Estimate against measurement, compound 4: 1.8-fold (0.25 log units) above; the measured number falls inside the stated range.
By their numbers in this assay, from the lowest: compound 3; then compounds 4 and 1 (each within the scatter of the next); then compound 2.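

In this assay, within the data shown here, putting methoxycarbonyl in place of fluoro gives a 2.2-fold lower number from compound 2 to compound 4 (0.35 log units; beyond the scatter) and so provides the first step here between two compounds that differ in one place. The step is modest, but it shows that the group on this aromatic carbon, para to a large group, affects the read-out. A group with more heavy atoms and with hydrogen-bond acceptors is also compatible with stronger inhibition than fluoro gives at this position, although no measurement shown here explains the change.

A single swap cannot show whether this gain is specific to methoxycarbonyl or would appear with other groups in place of fluoro. A carboxylic acid, an amide or a methyl group at the same position would help to separate these possibilities.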